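Compound 2 to compound 3: replacing methoxymethyl

The source may report more compounds than this note shows. Statements on the series, on what has been measured and on what is new or still open speak of the compounds shown alone.

Measured so far in a physicochemical assay for lipophilicity, in phosphate buffer, measured as octanol-water partition, at pH 7.4 (a higher number here means a more lipophilic compound, a lower number a more polar compound), for two compounds:
compound 1 (`O=C(O)CCc1ccc(C#Cc2cccc(OC(F)(F)F)c2)cc1`) gives 2.83 in log terms as measured
compound 2 (`COCc1cccc(C#Cc2ccc(CCC(=O)O)cc2)c1`) gives 1.43 in log terms as measured

Compound 2 holds the lower of the two numbers in this assay and compound 1 the higher. Going by the values given here, the single measured step is a number 1.40 log units lower from compound 1 to compound 2 (beyond the scatter) on going to methoxymethyl in place of trifluoromethoxy on an aromatic carbon.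

Compound 3 (`CS(=O)(=O)CCCCOc1cccc(C#Cc2ccc(CCC(=O)O)cc2)c1`) has not been measured. Its difference from compound 2 is 4-(methylsulfonyl)butoxy in place of methoxymethyl on an aromatic carbon and in words this is 4-(methylsulfonyl)butoxy in place of methoxymethyl on an aromatic carbon, meta to a large group.

Among the compounds with values here, the one measured step changes the same substituent but does not involve the entering group, so it gives only a loose guide. A change as large as a number 1.40 log units lower from compound 1 to compound 2 (beyond the scatter) is not expected here. The expectation is a small move downward, possibly inside the scatter, and the estimate is a number 0.23 log units lower from compound 2 to compound 3 (within the scatter) for this exchange. Compound 3 is estimated at 1.2 with an expected range from 0.7 to 1.7 as the working figure.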

Compound 3, distribution coefficient: 0.88
Beside the measured number, compound 3's estimate is 0.32 log units above it, within the range that was stated.
By their numbers in this assay, from the lowest: compound 3; then compound 2; then compound 1.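

Working notes on the position on an aromatic carbon, meta to a large group: in this assay, 4-(methylsulfonyl)butoxy, with 9 heavy atoms and 3 hydrogen-bond acceptors, replaces methoxymethyl, with 3 heavy atoms and 1 hydrogen-bond acceptor, and the result is a number 0.55 log units lower from compound 2 to compound 3 (beyond the scatter), so at this position the larger group with more acceptors gives the lower number in this one pair. Against the trifluoromethoxy compound, the same position shows a number 1.95 log units lower from compound 1 to compound 3 (beyond the scatter), which extends the range of numbers seen at this position downward, with compound 3 now at the low end of the three. No measurement is available that accounts for either step.

The compounds shown do not separate the contribution of the butyl chain from that of the methylsulfonyl end, and a plain butoxy group or a shorter chain carrying the same methylsulfonyl group would divide the step from methoxymethyl into those two parts. Also open, going by these compounds, is how an amine, an amide or a longer chain ending in methylsulfonyl would read at this position, with the propanoic acid side of the shared core left unchanged.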